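Cyano for bromo: cytotoxicity outlook for compound 4

The source may report more compounds than this note shows. Statements on the series, on what has been measured and on what is new or still open speak of the compounds shown alone.

Measured so far:
Compound 1 `Cc1cc(S(N)(=O)=O)ccc1NC(=O)COc1ccc(F)cc1Oc1ccc2cc(Br)ccc2c1` — in an ADME assay on C8166 cells (Homo sapiens) for cytotoxicity, read by MTT assay (on this read-out lower numbers stand for higher toxicity in this test and higher numbers for lower toxicity in this test), compound 1 gives > 357000 nM, a limit of the assay rather than a number.
Compound 2 `Cc1cc(S(N)(=O)=O)ccc1NC(=O)COc1ccc(F)cc1Oc1ccc2cc(C#N)ccc2c1` — in this assay compound 2 gives > 395000 nM, again a limit of the assay.
Compound 3 `Cc1cc(S(N)(=O)=O)ccc1NC(=O)COc1ccc(F)cc1Oc1ccc2cc(Br)ccc2c1Cl` — in this assay compound 3 gives 195000 nM.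

Compound 3 therefore stands as the only compound of the three with a read number; the other two values are limits, as shown by the limit of > 357000 nM in this assay, at which 1 of the 3 values shown sits, and by the limit of > 395000 nM in this assay, at which 1 of the 3 values shown sits.

Compound 4 `Cc1cc(S(N)(=O)=O)ccc1NC(=O)COc1ccc(F)cc1Oc1ccc2cc(C#N)ccc2c1Cl` differs from compound 3 by cyano in place of bromo on an aromatic carbon. The same swap has been made once already, from compound 1 to compound 2, but a step that the two limits leave unreadable from compound 1 to compound 2, so its size is not known. The two steps that reach compound 3 are an at least 1.8-fold lower number from compound 1 to compound 3 (0.26 log units; that floor lies within the scatter) and an at least 2.0-fold lower number from compound 2 to compound 3 (0.30 log units; that floor lies within the scatter); both are only floors, and both floors lie within the scatter, so they give no firm direction either. On this evidence no step beyond the scatter is expected; the estimate means a 1.3-fold higher number from compound 3 to compound 4 (0.11 log units; within the scatter). For compound 4 the expected value in this assay is 250000 nM, with a range from 120000 nM to 500000 nM, and a fair chance that only a limit is reported, as for compound 2.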

Compound 4, half-maximal cytotoxic concentration: 39700 nM
For compound 4 the middle estimate is 6.3-fold (0.80 log units) above the measured one; the whole stated range lies above it.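

With the chloro group present, cyano in place of bromo on this aromatic carbon now has a readable size in this assay: a 4.9-fold lower number from compound 3 to compound 4 (0.69 log units; beyond the scatter), pointing to higher toxicity in this test. The chloro group also gives a step beyond the scatter on the cyano-bearing core, an at least 9.9-fold lower number from compound 2 to compound 4 (0.99 log units; beyond the scatter), so the two changes together separate compound 4 from compound 2 and compound 3. Whether the chloro step depends on the group that cyano replaced stays undecided: the same change on two cores in this assay, an at least 1.8-fold lower number (0.26 log units; that floor lies within the scatter) from compound 1 to compound 3 and an at least 9.9-fold lower number (0.99 log units; beyond the scatter) from compound 2 to compound 4; the limit leaves it open whether they differ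

As far as these compounds go, the step from compound 1 to compound 2 cannot be read, so the effect of the same swap without the chloro group remains open. The compounds shown also leave open how an amine or a carboxylic acid on this aromatic carbon would read in this assay.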